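Dropping the tert-butyl of compound 3: a limit expected

The source may report more compounds than this note shows. Statements on the series, on what has been measured and on what is new or still open speak of the compounds shown alone.

Compound 1, `COc1cc(-c2ccnc3c(-c4ccc(C)cc4)cnn23)cc(OC)c1OC`, reaches only the limit of > 10000 nM in a functional assay on B16-F0 cells (Mus musculus) for inhibition, read by CCK-8 assay, with a stated time of 48 h; on this read-out lower numbers stand for stronger inhibition and higher numbers for weaker inhibition.
Compound 2, `COc1ccc(-c2cc3nccc(-c4cc(OC)c(OC)c(OC)c4)n3n2)cc1[N+](=O)[O-]`, likewise reaches only the limit of > 10000 nM in this assay.
Compound 3, `COc1cc(-c2ccnc3cc(-c4ccc(C(C)(C)C)cc4)nn23)cc(OC)c1OC`, also reaches only the limit of > 10000 nM in this assay.

Each of these three results is a limit of the assay, not a measured number. Compound 3 stands nowhere apart from the others: it sits at the limit of > 10000 nM in this assay, at which 3 of the 3 values shown sit, and no ordering among the three can be read from such results. Compound 4, `COc1cc(-c2ccnc3cc(-c4ccccc4)nn23)cc(OC)c1OC`, has not yet been measured. It differs from compound 3 in one place: hydrogen in place of tert-butyl on an aromatic carbon. Among the compounds with values here, all three measured compounds stop at the same limit, and no step between measured compounds is available as a guide. The step that the limit leaves unreadable from compound 3 to compound 4 is expected to be none beyond the usual scatter, with compound 4 expected to reach only the limit once more. The estimate for compound 4 in this assay is 15000 nM, with a range from 5000 nM to 50000 nM.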

Compound 4, half-maximal inhibitory concentration: 4730 nM
The estimate for compound 4 lay 3.2-fold (0.50 log units) above the measured number; the measured number lies below the stated range.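

Within the data shown here, replacing 4-(tert-butyl)phenyl with phenyl gives an at least 2.1-fold lower number from compound 3 to compound 4 (0.32 log units; beyond the scatter) in this assay, so this position on the aromatic ring does respond to a change of group, which the earlier compounds could not show. Compound 4 is the only compound shown that gives a measured number and not a limit of the assay: the limit of > 10000 nM in this assay, at which 3 of the 4 values shown sit. This is a single pair, so the result holds for tert-butyl and hydrogen at this position and says nothing yet about large groups in general.

Going by these compounds, it remains open how the number moves with other groups at this position, such as a fluorine, a methoxy or an amine, and whether any of them would go lower than compound 4. On these data alone, the full size of the step also stays unknown: compound 3 gives only a limit.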